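A few compounds are considered here, and "the series" means these few. Any claim that something is new, unique, unknown or untested is made for them only; others in the source may bear on it.

Measured compounds:
compound 1 `CC(=O)N1CCc2c(sc(NC(=O)c3ccc(Cl)cc3)c2C(N)=O)C1`, 38.4%
compound 2 `NC(=O)c1c(NC(=O)c2ccc(Oc3ccccc3)cc2)sc2c1CCN(C(=O)c1ccccc1)C2`, 4.71%

Of the compounds shown here, two of a shared core have been tested in an ADME assay on RAW264.7 cells (Mus musculus) for cytotoxicity, read by MTT assay, with a stated time of 48 h, tested at 50 uM; on this read-out higher numbers stand for more inhibition at the one concentration tested (going by the name of the read-out) and lower numbers for less inhibition. Compound 1 `CC(=O)N1CCc2c(sc(NC(=O)c3ccc(Cl)cc3)c2C(N)=O)C1` gives 38.4% in this assay. Among the measured compounds shown here, compound 2 `NC(=O)c1c(NC(=O)c2ccc(Oc3ccccc3)cc2)sc2c1CCN(C(=O)c1ccccc1)C2` gives 4.71% in this assay and so stands lowest of the two numbers; the gap to compound 1, its only neighbour, lies beyond the usual scatter. For the measured compounds named here, since compound 1 and compound 2 differ in two places, no single step between them can be drawn, and their two values are all that the pair shows.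

Compound 3 `CC(=O)N1CCc2c(sc(NC(=O)c3ccc(Oc4ccccc4)cc3)c2C(N)=O)C1` has not yet been measured. It differs from compound 2 in one place: methyl in place of phenyl on a carbonyl carbon. Compound 3 thus carries the acetyl seen in compound 1 together with the phenoxy group seen in compound 2. Going by the values given here, with no step of this kind measured, the expectation rests on the two values alone. An increase from compound 2 is expected, a number 15.3 percentage points higher from compound 2 to compound 3 (beyond the scatter), of moderate size, but with wide uncertainty. Compound 3 is estimated at 20% in this assay, within a range from 2% to 42%.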

Compound 3, a percentage reported as inhibition, at one concentration (the size of the read-out at that concentration, not a potency): 32.9%
Estimate against measurement, compound 3: 12.9 percentage points below; measured number inside the range.
By their numbers in this assay, from the lowest: compound 2; then compounds 3 and 1 (each within the scatter of the next).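

In this assay, the benzoyl to acetyl change, on a carbonyl carbon whose other neighbours are an amide-type nitrogen in a ring, now has a measured size with the phenoxy group held fixed: a number 28.2 percentage points higher from compound 2 to compound 3 (beyond the scatter). This shows that the group at this position can shift the read-out on its own. Among the compounds shown here, the other single change, phenoxy in place of chloro on an aromatic carbon with the acetyl held fixed, gives a number 5.5 percentage points lower from compound 1 to compound 3 (within the scatter), so this read-out does not tell those two groups apart, and of the two single changes only the one at the carbonyl carbon lies beyond the scatter. No measurement at hand speaks to what lies behind either step.

The compounds shown leave open whether the benzoyl to acetyl step would keep its size with chloro in place of phenoxy on the aromatic carbon. They also leave open how the number would run with a longer acyl chain such as butyryl at the carbonyl carbon, or with an amine or a carboxylic acid carried on that acyl group.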